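Trimming a furanylmethyl arm down to a methyl

A few compounds are considered here, and "the series" means these few. Any claim that something is new, unique, unknown or untested is made for them only; others in the source may bear on it.

Compound 3 `Cc1ccc2c(NCc3ccc(NC(=O)C4CCN(Cc5ccco5)CC4)cc3)nc(N(C)C)nc2c1` was tested in a functional assay on SV5A8 cells (Homo sapiens) for cytotoxicity; on this read-out lower numbers stand for stronger inhibition and higher numbers for weaker inhibition. In this assay compound 3 gives > 20000 nM, which is a limit of the assay rather than a number. Compound 1 `Cc1ccc2c(NCc3ccc(NC(=O)C4CCN(Cc5ncc[nH]5)CC4)cc3)nc(N(C)C)nc2c1` gives > 20000 nM, also a limit. Compound 2 `Cc1ccc2c(NCc3ccc(NC(=O)C4CCN(Cc5cc(Cl)ccn5)CC4)cc3)nc(N(C)C)nc2c1` gives > 5400 nM, likewise a limit. The steps a step that the two limits leave unreadable from compound 1 to compound 2, a step that the two limits leave unreadable from compound 1 to compound 3 and a step that the two limits leave unreadable from compound 2 to compound 3 are therefore not readable in size, since every value sits at the limit of > 20000 nM in this assay, at which 2 of the 3 values shown sit, or at the limit of > 5400 nM in this assay, at which 1 of the 3 values shown sits. Compound 4 `Cc1ccc2c(NCc3ccc(NC(=O)C4CCN(C)CC4)cc3)nc(N(C)C)nc2c1` carries the change (hydrogen in place of furan-2-yl on a saturated chain carbon bound to an amine nitrogen in a ring), so that (furan-2-yl)methyl becomes methyl. Among the measured compounds shown here, no measured step gives a readable effect of varying this group, so compound 4 is expected to remain near the limit, the step of a number no higher from compound 3 to compound 4 (the limit leaves the size open) being expected as none beyond the scatter. Compound 4 is estimated at 20000 nM, between 5000 nM and 60000 nM.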

Compound 4, half-maximal inhibitory concentration: > 17300 nM
Compound 4 was reported as a limit; the forecaster's own chance of this, stated with the estimate: 85%; the middle value lies beyond the limit too.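

Compound 4, like compound 1, compound 2 and compound 3, is reported only as a limit, so none of its steps from those three can be read in size: the limit of > 17300 nM in this assay, at which 1 of the 4 values shown sits. The compounds shown leave open whether changing this group alters cytotoxicity at all.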